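The source may report more compounds than this note shows. Statements on the series, on what has been measured and on what is new or still open speak of the compounds shown alone.

For the measured compounds named here, in a physicochemical assay for acid dissociation, compound 2 (`CC(C)n1cc(-c2ccnc3[nH]c(C4CCN(Cc5cccs5)CC4)cc23)ccc1=O`) reads 6.5 and is the lower of the two measured compounds, with compound 1 (`CNC(=O)CN1CCC(c2cc3c(-c4ccc(=O)n(C(C)C)c4)ccnc3[nH]2)CC1`) at 6.9 as its only neighbour. Compound 3 (`CC(C)n1cc(-c2ccnc3[nH]c(C4CCN(CC(=O)N5CCCCC5)CC4)cc23)ccc1=O`) carries (piperidin-1-yl)carbonyl in place of thiophen-2-yl on a saturated chain carbon bound to an amine nitrogen in a ring. Going by the values given here, the one measured step that bears on this is a number 0.40 log units lower from compound 1 to compound 2 (beyond the scatter) (a modest one), where thiophen-2-yl replaced methylcarbamoyl at that same place. Compound 3 swaps thiophen-2-yl for another carbonyl group, so a step of similar size in the opposite direction is expected in this assay (a number 0.40 log units higher from compound 2 to compound 3 (beyond the scatter)). The estimate for compound 3 is 6.9 (expected range 6.5 to 7.3).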

Compound 3, acid dissociation constant: 7.8
Compound 3: middle estimate off by 0.90 log units, on the low side; the whole stated range lies below it.
By their numbers in this assay, from the lowest: compound 2; then compound 1; then compound 3.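

In this assay, the place on a saturated chain carbon bound to an amine nitrogen in a ring proves more sensitive than compounds 1 and 2 alone suggested, with a number 1.30 log units higher from compound 2 to compound 3 (beyond the scatter) for the change from thiophen-2-yl to (piperidin-1-yl)carbonyl. The carbonyl alone does not set the number, since a number 0.90 log units higher from compound 1 to compound 3 (beyond the scatter) when piperidin-1-yl replaces methylamino on the carbonyl carbon. No evidence given here accounts for either step. From the compounds shown here alone, how a morpholin-4-yl group on that carbonyl carbon, or a carboxylic acid at that same place, would read remains open.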